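A few compounds are considered here, and "the series" means these few. Any claim that something is new, unique, unknown or untested is made for them only; others in the source may bear on it.

Compound 1, `CC1(Sc2ccccc2)C(=O)N(c2ccccc2)c2ncccc21`: 0%
Compound 2, `CC1(C)C(=O)N(c2ccccc2Cl)c2ncccc21`: 3%
Compound 3, `CC1(C)C(=O)N(c2ccc(S(C)(=O)=O)cc2)c2ncccc21`: 0%

All three compounds share one core and were tested in a functional assay on the whole organism (Pleural cavity) for inhibition, with Rattus norvegicus as the target, at a dose of 25 mg/kg; on this read-out higher numbers stand for more inhibition at the one dose given (going by the name of the read-out) and lower numbers for less inhibition. In this assay compound 3 gives 0%, level with compound 1 at the digits shown, and together these two are the lowest of the three numbers. Compound 2 lies within the scatter of both, so no order among the three can be read from these data, and none of them shows inhibition beyond the scatter.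

Compound 4, `COc1ccc(N2C(=O)C(C)(C)c3cccnc32)cc1`, has not yet been measured in this assay. It differs from compound 3 in one place: methoxy in place of methylsulfonyl on an aromatic carbon. For the measured compounds named here, no step between measured compounds with this change is available, so the expectation rests only on the three numbers in hand. Because compound 3 gives 0%, and compounds 1 and 2 likewise show nothing beyond the scatter, the step from compound 3 to compound 4 is expected to be a number 4 percentage points higher from compound 3 to compound 4 (within the scatter), that is, none beyond the scatter. Compound 4 is therefore estimated at 4%, with a range from -10% to 20%.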

Compound 4, a percentage reported as inhibition, in the whole organism at one dose (the size of the read-out at that dose, not a potency): 42%
For compound 4 the middle estimate is 38 percentage points below the measured one, and the stated range ends below it.
By their numbers in this assay, from the lowest: compounds 1, 3 and 2 (each within the scatter of the next); then compound 4.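

In this assay, methoxy in place of methylsulfonyl on this aromatic carbon, para to a large group, gives a number 42 percentage points higher from compound 3 to compound 4 (beyond the scatter). For the compounds shown here, this is the first step that can be read, and it shows that the group at this place can separate a compound with no inhibition beyond the scatter from one with clear inhibition at the single dose, on an otherwise unchanged core. The entering group is also smaller and carries fewer hydrogen-bond acceptors, but no measurement shown here ties the rise to either difference or to anything else.

Whether the inhibition is specific to methoxy stays open, since no amine, hydroxyl or longer ethoxy chain at this place is shown. Also open, as far as these compounds go, is whether methoxy would give a similar step elsewhere on this ring.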